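A few compounds are considered here, and "the series" means these few. Any claim that something is new, unique, unknown or untested is made for them only; others in the source may bear on it.

Compound 3, `CO[C@H]1CC[C@H](NC(=O)c2n[nH]cc2NC(=O)c2ccccc2)CC1`, is the compound with the lowest number among the three measured here: in an ADME assay on MRC5 cells (Homo sapiens) for inhibition, with a stated time of 72 h (a higher number here means that more compound is needed for the effect, a lower number that less compound is needed), compound 3 gives 800 nM. Its nearest neighbour is compound 2, `CO[C@H]1CC[C@H](NC(=O)c2n[nH]cc2NC(=O)c2cc3ccccn3n2)CC1`, which in this assay gives 1000 nM, a gap that is within the scatter (a 1.3-fold lower number from compound 2 to compound 3 (0.10 log units; within the scatter)). Compound 1, `CO[C@H]1CC[C@H](NC(=O)c2n[nH]cc2NC(=O)c2ccc(F)cc2F)CC1`, gives 11000 nM in this assay, and the step from it is large (a 14-fold lower number from compound 1 to compound 3 (1.14 log units; beyond the scatter)).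

Compound 4 is `CO[C@H]1CC[C@H](NC(=O)c2n[nH]cc2NC(=O)C2CCC(F)(F)CC2)CC1`. The change from compound 3 is 4,4-difluorocyclohexyl in place of phenyl on a carbonyl carbon. Among the compounds with values here, no measured step swaps an aromatic ring for a non-aromatic one, so nothing bears on it directly. The step of a 14-fold lower number from compound 1 to compound 3 (1.14 log units; beyond the scatter) shows that two fluorine atoms on the phenyl went with a much higher number, whereas a 1.3-fold lower number from compound 2 to compound 3 (0.10 log units; within the scatter) shows the ring choice itself mattered little in that case. A modest rise toward a higher number is expected for compound 4, of the size a 3.1-fold higher number from compound 3 to compound 4 (0.49 log units; beyond the scatter), with wide uncertainty. Compound 4 is estimated at 2500 nM, in the range 800 nM to 8000 nM.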

Compound 4, half-maximal effective concentration: > 50000 nM
Compound 4: only a limit was reported; the forecaster's own chance of this, stated with the estimate: 10%; middle value at least 20-fold (1.30 log units) from the limit.
By their numbers in this assay, from the lowest: compounds 3 and 2 (each within the scatter of the next); then compound 1. At a limit, above all of these: compound 4.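

Compound 4 reads only as a limit, not as a number: the limit of > 50000 nM in this assay, at which 1 of the 4 values shown sits.

This is the first non-aromatic ring shown on this carbonyl carbon, and in this assay the change gives an at least 62-fold higher number from compound 3 to compound 4 (1.79 log units; beyond the scatter) and an at least 50-fold higher number from compound 2 to compound 4 (1.69 log units; beyond the scatter), far larger than the swap between aromatic groups, a 1.3-fold lower number from compound 2 to compound 3 (0.10 log units; within the scatter). Even 2,4-difluorophenyl, the aromatic group with the highest number here, gives an at least 4.5-fold higher number from compound 1 to compound 4 (0.65 log units; beyond the scatter), so all three aromatic groups shown stand below 4,4-difluorocyclohexyl at this position.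

Going by these compounds, whether the rise belongs to the loss of the aromatic ring or to the two fluorine atoms stays open, and a plain cyclohexyl group on this carbonyl carbon would separate the two. On these data alone, how a pyridyl group would read at this position also stays open.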